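This account rests on a few compounds, and the source may have more. Where it says the series, first, only, none or still open, it means among the compounds named here.

In a functional assay on KM12 cells (Homo sapiens) for inhibition, read by sulforhodamine B assay, with a stated time of 48 h (a higher number here means that more compound is tolerated, a lower number that less compound is tolerated), three compounds have been measured so far, and two of them reach only a limit of the method. Compound 1 `O=C(Nc1cccc(-n2cc(-c3ccncc3)c(-c3ccc(Cl)c(O)c3)n2)c1)Nc1cccc(C(F)(F)F)c1` gives > 32500 nM, which is a limit rather than a number, sitting at the limit of > 32500 nM in this assay, at which 1 of the 3 values shown sits. Within the data shown here, compound 2 `COc1cc(-c2nn(-c3cccc(NC(=O)Nc4cc(C(F)(F)F)cc(C(F)(F)F)c4)c3)cc2-c2ccncc2)ccc1Cl` gives 3390 nM, the only reading that is a true number among the three. Compound 3 `COc1cc(-c2nn(-c3cccc(NC(=O)c4cccc(C(F)(F)F)c4)c3)cc2-c2ccncc2)ccc1Cl` gives > 50000 nM, again a limit and not a number, sitting at the limit of > 50000 nM in this assay, at which 1 of the 3 values shown sits. Compound 3 therefore stands at the edge of what this assay can report, and only compound 2 offers a measured point to compare against.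

Compound 4 `COc1cc(-c2nn(-c3cccc(NC(=O)Nc4ccc(Cl)c(Cl)c4)c3)cc2-c2ccncc2)ccc1Cl` has not yet been measured. It differs from compound 3 in one place: (3,4-dichlorophenyl)amino in place of 3-(trifluoromethyl)phenyl on a carbonyl carbon. Among the measured compounds shown here, no step between two measured compounds covers this change directly. Compound 4 is nonetheless expected to tolerate less compound than compound 3 because compound 2 with its carbamoyl linkage gives 3390 nM. The step from compound 3 to compound 4 is expected to be an at least 10-fold lower number from compound 3 to compound 4 (1.00 log units; beyond the scatter), well beyond the usual scatter. Compound 4 is estimated at 5000 nM, with a range from 1500 nM to 20000 nM.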

Compound 4, concentration lethal to 50% of the cells: 49500 nM
Beside the measured number, compound 4's estimate is 9.9-fold (1.00 log units) below it; measured number above the stated range.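

In this assay, putting (3,4-dichlorophenyl)amino in place of 3-(trifluoromethyl)phenyl on a carbonyl carbon gives a number no higher from compound 3 to compound 4 (the limit leaves the size open), so the change does not raise the number, but whether it lowers it at all cannot be read. Compound 3 gives > 50000 nM, which is a limit of the method and not a number: the limit of > 50000 nM in this assay, at which 1 of the 4 values shown sits. Compound 4, with its (3,4-dichlorophenyl)carbamoyl group, gives 49500 nM, whereas compound 2, which also carries a carbamoyl group but with a different ring, gives 3390 nM, so the carbamoyl group alone does not set the reading.

The change from compound 3 to compound 4 alters the ring's substituents and adds the nitrogen at once, leaving open which of the two matters, and a 3-(trifluoromethyl)phenyl ring on the same carbamoyl would separate them. Also open, from the compounds shown here alone, is how the reading in this assay would respond to a ring bearing an amine or a carboxylic acid, or to a longer chain in place of the ring.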